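The source may hold more compounds than are shown below. What is called first, only, known or untested is meant among the compounds shown, and "the series" means these compounds.

Measured so far in a functional assay on NCI-H460 cells (Homo sapiens) for antiproliferative activity, read by MTT assay, with a stated time of 72 h; a higher number here means a weaker inhibitor, a lower number a stronger inhibitor:
compound 1 `CN(C)CCn1cnnc1-c1cc(Oc2ccc(NC(=O)Nc3ccc(F)c(Cl)c3)cc2F)ccn1` gives 1580 nM;
compound 2 `CCN(CC)CCn1cnnc1-c1cc(Oc2ccc(NC(=O)Nc3cccc(C(F)(F)F)c3)cc2F)ccn1` gives 9870 nM;
compound 3 `CCN(CC)CCn1cnnc1-c1cc(Oc2ccc(NC(=O)Nc3ccccc3C(F)(F)F)cc2F)ccn1` gives > 50000 nM, a limit of the assay and not a number.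

Compound 3 thus sits at the limit of > 50000 nM in this assay, at which 1 of the 3 values shown sits. Going by the values given here, the one measured step, an at least 5.0-fold higher number from compound 2 to compound 3 (0.70 log units; beyond the scatter), was a weakening on moving to 2-(trifluoromethyl)phenyl. Compound 4 `CCN(CC)CCn1cnnc1-c1cc(Oc2ccc(NC(=O)Nc3ccc(F)c(Cl)c3)cc2F)ccn1` carries 3-chloro-4-fluorophenyl in place of 2-(trifluoromethyl)phenyl on an amide-type nitrogen. Among the compounds with values here, no measured step covers this exact exchange, but compound 1 bears the same 3-chloro-4-fluorophenyl group and differs from compound 4 only elsewhere in the molecule; in this assay compound 1 gives 1580 nM. The expected step is an at least 20-fold lower number from compound 3 to compound 4 (1.30 log units; beyond the scatter), towards a lower number. Compound 4 is expected at 2500 nM, within 800 nM to 8000 nM.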

Compound 4, half-maximal inhibitory concentration: 7390 nM
Compound 4: middle estimate off by 3.0-fold (0.47 log units), on the low side, and the stated range covers the measured number.
By their numbers in this assay, from the lowest: compound 1; then compounds 4 and 2 (each within the scatter of the next). At a limit, above all of these: compound 3.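

In this assay, 3-chloro-4-fluorophenyl and 3-(trifluoromethyl)phenyl on the amide-type nitrogen read alike, a 1.3-fold lower number from compound 2 to compound 4 (0.13 log units; within the scatter), while leaving 2-(trifluoromethyl)phenyl gives an at least 6.7-fold lower number from compound 3 to compound 4 (0.83 log units; beyond the scatter). Compound 3 stands at a limit of the assay and not a number: the limit of > 50000 nM in this assay, at which 1 of the 4 values shown sits. With 3-chloro-4-fluorophenyl held fixed, diethylamino in place of dimethylamino gives a 4.7-fold higher number from compound 1 to compound 4 (0.67 log units; beyond the scatter), so the chain end also moves the number.

Open, from the compounds shown here alone, is how a morpholine at the chain end would read. Also open, going by these compounds, is how an unsubstituted phenyl on the amide-type nitrogen would compare.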